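From bromo to ethoxy: a step outside the measured range

A few compounds are considered here, and "the series" means these few. Any claim that something is new, unique, unknown or untested is made for them only; others in the source may bear on it.

Compound 1 `CSc1nc(Nc2ccc(Cl)cc2)c2cccnc2n1` – 8510 nM
Compound 2 `CSc1nc(Nc2ccc(Br)cc2)c2cccnc2n1` – 5750 nM

In a functional assay (Nicotiana tabacum) (a higher number here means a weaker inhibitor, a lower number a stronger inhibitor), compound 1 gives 8510 nM and compound 2 gives 5750 nM. For the measured compounds named here, the only measured step, a 1.5-fold lower number from compound 1 to compound 2 (0.17 log units; within the scatter), lies within the scatter, so compound 2 stands together with compound 1 and the two are not distinguished by these numbers.

Compound 3 `CCOc1ccc(Nc2nc(SC)nc3ncccc23)cc1` is the unmeasured compound. It differs from compound 2 as follows: ethoxy in place of bromo on an aromatic carbon. Going by the values given here, the one measured step exchanges one halogen for another; no step exchanges a halogen for an ethoxy group, so nothing measured bears directly on this change. Among the compounds with values here, since the single change on that carbon left a 1.5-fold lower number from compound 1 to compound 2 (0.17 log units; within the scatter) within the scatter, the expectation is a step of a 1.1-fold higher number from compound 2 to compound 3 (0.05 log units; within the scatter) in this assay, with a wide range to reflect the untested group. Compound 3 is therefore estimated at 6500 nM in this assay, between 2000 nM and 25000 nM.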

Compound 3, half-maximal inhibitory concentration: 5420 nM
The estimate for compound 3 lay 1.2-fold (0.08 log units) above the measured number; the measured number falls inside the stated range.
By their numbers in this assay, from the lowest: compounds 3, 2 and 1 (each within the scatter of the next).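

In this assay, ethoxy in place of bromo on this aromatic carbon, para to a large group, gives a 1.1-fold lower number from compound 2 to compound 3 (0.03 log units; within the scatter), and ethoxy in place of chloro gives a 1.6-fold lower number from compound 1 to compound 3 (0.20 log units; within the scatter). The earlier pair showed only one halogen exchanged for another, whereas these steps show that a group with no halogen, with 3 heavy atoms and 1 hydrogen-bond acceptor, also stands within the scatter of both halogen compounds. No supporting information bears on why these three compounds are not distinguished.

The compounds shown leave open whether an amine, a carboxylic acid or a chain longer than ethoxy on this carbon would stand apart from these three. They also leave open whether a change elsewhere on the shared core would separate the numbers.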